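Shortening the Ester Chain from Compound 3 to Compound 4

A few compounds are considered here, and "the series" means these few. Any claim that something is new, unique, unknown or untested is made for them only; others in the source may bear on it.

Of the compounds shown here, three sharing one core have been measured in an assay on membranes from HeLa cells for displacement of a labelled ligand from adenosine receptor A3 (Homo sapiens), read by scintillation counting, with a stated time of 180 min, tested at 1 uM; a lower number here means less inhibition, a higher number more inhibition at the concentration tested (going by the name of the read-out). Compound 1 `CCNC(=O)C1=C(C)NC(=O)NC1c1cccs1` gives 4%, compound 2 `CCSC(=O)C1=C(C)NC(=O)NC1c1cccs1` gives 1%, and compound 3 `CCC(CC)OC(=O)C1=C(C)NC(=O)NC1c1cccs1` gives 1%. Compound 3 therefore stands level with compound 2 at the digits reported, the two of them together the lowest of the three numbers, while the step of a number 3 percentage points lower from compound 1 to compound 3 (within the scatter) lies within the scatter.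

Compound 4 `CCC(C)OC(=O)C1=C(C)NC(=O)NC1c1cccs1` differs from compound 3 by hydrogen in place of methyl on a saturated chain carbon, two bonds along the chain from an oxygen next to a carbonyl group. Among the measured compounds shown here, none of the measured steps touches this part of the molecule; all of them exchange the group on the carbonyl carbon, namely a number 3 percentage points lower from compound 1 to compound 2 (within the scatter), a number 3 percentage points lower from compound 1 to compound 3 (within the scatter) and no change at the digits printed from compound 2 to compound 3 (within the scatter), and every one lies within the scatter. With nothing in the data pointing to movement, the step from compound 3 to compound 4 is expected to be no change at the digits printed from compound 3 to compound 4 (within the scatter), none beyond the scatter. Compound 4 is thus estimated at 1%, with a range from -8% to 10%.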

Compound 4, a percentage reported as inhibition, at one concentration (the size of the read-out at that concentration, not a potency): 7%
Beside the measured number, compound 4's estimate is 6 percentage points below it; the measured number falls inside the stated range.
By their numbers in this assay, from the lowest: compounds 2, 3, 1 and 4 (each within the scatter of the next).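

In this assay, among the compounds shown here, replacing (pentan-3-yl)oxy by sec-butoxy gives a number 6 percentage points higher from compound 3 to compound 4 (within the scatter), so the first change at this saturated chain carbon, two bonds along the chain from an oxygen next to a carbonyl group, stays inside the scatter, as the exchanges on the carbonyl carbon did. The sec-butoxy group also stands within the scatter of the other two groups on the carbonyl carbon, with a number 6 percentage points higher from compound 2 to compound 4 (within the scatter) and a number 3 percentage points higher from compound 1 to compound 4 (within the scatter), so neither kind of change separates these four compounds at the concentration tested. No measurement at hand offers an explanation for these numbers.

From the compounds shown here alone, whether a benzyloxy group, a longer chain or a carboxylic acid in this place would lift inhibition clear of the scatter stays open. These readings at a single concentration also give no potency for any of the four compounds.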